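The compounds below may be only part of what the source reports. "The series", "measured", "known", "first", "only" and "open" are said of these compounds alone.

In a functional assay on ACHN cells (Homo sapiens) for cytotoxicity, read by MTT assay, with a stated time of 48 h (a lower number here means a stronger inhibitor, a higher number a weaker inhibitor), the measured compounds are:

compound 1, `COc1ccc(-c2cc(C(=O)Nc3nc4ccc(F)cc4s3)nc3cc(-c4ccccc4)nn23)cc1OC`, which gives 8120 nM;
compound 2, `COc1cc(-c2cc(C(=O)Nc3nc4ccc(F)cc4s3)nc3cc(-c4ccccc4)nn23)cc(OC)c1OC`, which gives 32400 nM;
compound 3, `COc1ccc(-c2cc(C(=O)Nc3nc4ccc(OC)cc4s3)nc3cc(-c4ccccc4)nn23)cc1`, which gives 38300 nM.

The one counted step among these is methoxy in place of hydrogen on an aromatic carbon, and it gave a 4.0-fold higher number from compound 1 to compound 2 (0.60 log units; beyond the scatter). The difference between the core of compound 3 and the core of compound 1 is not broken down here. Compound 4, `COc1ccc2nc(NC(=O)c3cc(-c4ccc(OC)c(OC)c4)n4nc(-c5ccccc5)cc4n3)sc2c1`, is not yet measured; it carries methoxy in place of hydrogen on an aromatic carbon, the same kind of change as between compound 1 and compound 2, though the place differs: in compound 2 the entering group is also meta to a methoxy group, which is not so in compound 4. Because a 4.0-fold higher number from compound 1 to compound 2 (0.60 log units; beyond the scatter) pointed toward a higher number, a step in the same direction is expected for compound 4, estimated as a 2.1-fold higher number from compound 3 to compound 4 (0.32 log units; beyond the scatter). Compound 4 is therefore expected to give about 80000 nM, likely between 25000 nM and 250000 nM.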

Compound 4, half-maximal inhibitory concentration: 13300 nM
For compound 4 the middle estimate is 6.0-fold (0.78 log units) above the measured one; measured number outside the range, below it.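

In this assay, the change 4-methoxyphenyl to 3,4-dimethoxyphenyl gives a 2.9-fold lower number from compound 3 to compound 4 (0.46 log units; beyond the scatter) and so runs opposite to the earlier methoxy step. Methoxy in place of fluoro on an aromatic carbon gives a 1.6-fold higher number from compound 1 to compound 4 (0.21 log units; within the scatter) and stays within the scatter. Methoxy in place of hydrogen on an aromatic carbon therefore did not carry from one core to the other, although these two steps do not show whether the core or the place of entry decides the outcome: the same change on two cores in this assay, a 4.0-fold higher number (0.60 log units; beyond the scatter) from compound 1 to compound 2 and a 2.9-fold lower number (0.46 log units; beyond the scatter) from compound 3 to compound 4, 11-fold (1.06 log units) apart, beyond the scatter of two such steps.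

As far as these compounds go, it remains open how a hydroxyl, a chlorine or an amine would behave at this place. From the compounds shown here alone, it also remains open how the 4-methoxyphenyl group would behave on the core of compound 1.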